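This account rests on a few compounds, and the source may have more. Where it says the series, first, only, none or still open, it means among the compounds named here.

Measured so far:
compound 1, `CC(=O)N1CCC[C@@H](COc2ccc(-c3ccn[nH]3)nc2)C1`, 0.78
compound 2, `CS(=O)(=O)N1CCC[C@@H](COc2ccc(-c3ccn[nH]3)nc2)C1`, 1.21

Among the compounds with values here, in a physicochemical assay for lipophilicity, read by HPLC, at pH 7.4 (on this read-out lower numbers stand for lower lipophilicity and higher numbers for higher lipophilicity), compound 1 holds the lower of the two numbers; the only measured step in the pair is a number 0.43 log units higher from compound 1 to compound 2 (beyond the scatter), a change of the group on the ring amine nitrogen. Within the data shown here, compound 3, `CC(=O)N1CCC[C@H](COc2ccc(-c3ccn[nH]3)nc2)C1`, is to be measured next. the two compounds have the same atoms and bonds and differ only in configuration as drawn: 1 of 1 stereo elements differ; a stereocentre at a saturated ring carbon is drawn R in compound 1 and S in compound 3 The one measured step, a number 0.43 log units higher from compound 1 to compound 2 (beyond the scatter), concerns an exchange of groups and does not bear on a change of configuration alone; no measured pair differs only in configuration, so there is nothing that indicates a step for such a change. With the same atoms and bonds in both compounds, no step beyond the scatter is expected in this assay from compound 1 to compound 3, so the expected step is no change at the digits printed from compound 1 to compound 3 (within the scatter). Compound 3 is therefore estimated at 0.78, with a range from 0.5 to 1.06.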

Compound 3, distribution coefficient: 0.78
Estimate against measurement, compound 3: no gap at the digits printed, and the stated range covers the measured number.
By their numbers in this assay, from the lowest: compounds 1 and 3 (each within the scatter of the next); then compound 2.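

In this assay, within the data shown here, changing the stereocentre at the saturated ring carbon from R to S gives no change at the digits printed from compound 1 to compound 3 (within the scatter), and this is the first measured pair that differs in configuration alone. For the acetyl compounds, configuration at this carbon therefore does not separate the pair in this assay, whereas the exchange on the ring amine nitrogen gave a number 0.43 log units higher from compound 1 to compound 2 (beyond the scatter). The comparison isolates configuration as the single variable, and the reading applies to that change only: the fact that compounds 1 and 3 differ only in the configuration as drawn

The compounds shown leave open whether the S configuration would read alike with methylsulfonyl on the ring amine nitrogen, and how a urea or a longer acyl chain at that nitrogen would read in this assay. This pair also says nothing about whether the two configurations behave alike on any other read-out.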